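This account rests on a few compounds, and the source may have more. Where it says the series, first, only, none or still open, it means among the compounds named here.

Measured so far in a functional assay on HL-60 cells (Homo sapiens) for antiproliferative activity, read by sulforhodamine B assay, with a stated time of 72 h; a higher number here means a weaker inhibitor, a lower number a stronger inhibitor:
- Compound 1 `Fc1ccccc1NC(=S)N/N=C/c1ccc2ccccc2n1`: > 100000 nM, a limit of the assay and not a number
- Compound 2 `COc1cccc(NC(=S)N/N=C/c2ccc3ccccc3n2)c1`: 71200 nM
- Compound 3 `Fc1ccc(NC(=S)N/N=C/c2ccc3ccccc3n2)cc1`: 17000 nM

Of the two true numbers in this assay, compound 3 has the lower, at 17000 nM. The next step leads to compound 4 `S=C(N/N=C/c1ccc2ccccc2n1)Nc1cccc(Cl)c1`, which carries 3-chlorophenyl in place of 4-fluorophenyl on an amide-type nitrogen.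

For the measured compounds named here, no measured step brings in 3-chlorophenyl, so the evidence is indirect. Two steps end at the 4-fluorophenyl of compound 3: a 4.2-fold lower number from compound 2 to compound 3 (0.62 log units; beyond the scatter) and an at least 5.8-fold lower number from compound 1 to compound 3 (0.76 log units; beyond the scatter). Both go towards a lower number, and the first starts from a ring with a group named at the same 3-position. Leaving 4-fluorophenyl is therefore expected to give back some of that gain, though probably not all of it, since the incoming group differs from those of compound 1 and compound 2. The expected change is small and upward: a 1.8-fold higher number from compound 3 to compound 4 (0.25 log units; within the scatter). For compound 4 the estimated value is 30000 nM, with an expected range from 8000 nM to 100000 nM.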

Compound 4, half-maximal inhibitory concentration: 28800 nM
Compound 4: middle estimate off by 1.0-fold (0.02 log units), on the high side; the measured number falls inside the stated range.
By their numbers in this assay, from the lowest: compounds 3 and 4 (each within the scatter of the next); then compound 2. At a limit, above all of these: compound 1.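

In this assay, the change to 3-chlorophenyl on an amide-type nitrogen leaves the number within the scatter (a 1.7-fold higher number from compound 3 to compound 4 (0.23 log units; within the scatter)), so this place tolerates a change of both halogen and ring position without a readable loss. Chloro in place of methoxy on an aromatic carbon is the first step that swaps only the group on the ring, and it is modest but beyond the scatter (a 2.5-fold lower number from compound 2 to compound 4 (0.39 log units; beyond the scatter)). The step from 2-fluorophenyl to 3-chlorophenyl gives only a floor (an at least 3.4-fold lower number from compound 1 to compound 4 (0.54 log units; beyond the scatter)), and compound 1 stands at a limit of the assay and not a number: the limit of > 100000 nM in this assay, at which 1 of the 4 values shown sits.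

From the compounds shown here alone, what 4-chlorophenyl or 3-fluorophenyl would give at this place stays open, so halogen and ring position cannot be separated between compound 3 and compound 4. Also open, going by these compounds, is how an amine or a carboxylic acid on this ring would read in this assay.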